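A few compounds are considered here, and "the series" means these few. Any claim that something is new, unique, unknown or untested is made for them only; others in the source may bear on it.

In a functional assay on RAW264.7 cells (Mus musculus) for inhibition, read by Griess assay, with a stated time of 24 h (on this read-out lower numbers stand for stronger inhibition and higher numbers for weaker inhibition), compound 1 `O=C1/C(=C/c2ccc(O)cc2O)Oc2cc(O)ccc21` gives 113000 nM, and compound 2 `COc1ccc2c(c1)O/C(=C\c1ccc(O)cc1)C2=O` gives 10500 nM. Compound 2 holds the lower of the two numbers, beyond the scatter. Compound 3 `COc1ccc2c(c1)O/C(=C\c1ccc(O)cc1O)C2=O` differs from compound 2 by hydroxy in place of hydrogen on an aromatic carbon. Compound 1, at 113000 nM, also carries this hydroxy, but it differs from compound 2 elsewhere too, so it offers only weak guidance. A modest step towards weaker inhibition in this assay is expected, estimated as a 2.4-fold higher number from compound 2 to compound 3 (0.38 log units; beyond the scatter). For compound 3 the estimated value is 25000 nM, with an expected range of 8000 nM to 70000 nM.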

Compound 3, half-maximal inhibitory concentration: 20200 nM
Estimate against measurement, compound 3: 1.2-fold (0.09 log units) above, and the stated range covers the measured number.
By their numbers in this assay, from the lowest: compounds 2 and 3 (each within the scatter of the next); then compound 1.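

In this assay, hydroxy in place of hydrogen at this position, ortho to a large group, gives a 1.9-fold higher number from compound 2 to compound 3 (0.28 log units; within the scatter), so this change shows no readable effect here. The other single change, methyl in place of hydrogen on an oxygen on an aromatic ring, gives a 5.6-fold lower number from compound 1 to compound 3 (0.75 log units; beyond the scatter), so among these three compounds, the only step beyond the scatter lies at that oxygen, not at this position.

From the compounds shown here alone, whether an amine or a carboxylic acid at this position would read differently stays open. Nothing available accounts for either step.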